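This account rests on a few compounds, and the source may have more. Where it says the series, first, only, none or still open, it means among the compounds named here.

Measured compounds:
compound 1, `CC1=CC[C@H](C(C)C)c2cc(C)c(OC(=O)c3ccc(C(F)(F)F)cc3)cc21`, 6.4%
compound 2, `Cc1cc2c(C(C)C)ccc(C)c2cc1OC(=O)c1ccc([N+](=O)[O-])cc1`, 97.6%
compound 3, `CC1=CC[C@H](C(C)C)c2cc(C)c(OC(=O)c3cccc(C(F)(F)F)c3)cc21`, 15%

The account follows a single change made to compound 1. In a functional assay on HCT-15 cells (Homo sapiens) for antiproliferative activity, read by sulforhodamine B assay, with a stated time of 48 h, tested at 50 uM (on this read-out higher numbers stand for more inhibition at the one concentration tested (going by the name of the read-out) and lower numbers for less inhibition), compound 1 gives 6.4%, the lowest of the three numbers recorded. Its nearest neighbour is compound 3, which gives 15%; the two numbers lie within the scatter of each other, so no order between compound 1 and compound 3 can be read from them. Furthest away is compound 2, which gives 97.6%, a number far beyond the scatter from that of compound 1; compound 2 carries a nitro group and a different core, and no single step links it to compound 1.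

Compound 4, `COc1ccc(C(=O)Oc2cc3c(cc2C)[C@@H](C(C)C)CC=C3C)cc1`, has not yet been measured. It differs from compound 1 in one place: methoxy in place of trifluoromethyl on an aromatic carbon. The group that enters sits on an aromatic carbon of a six-membered aromatic ring of carbon only, para to a large group.

Among the compounds with values here, nothing among the measured compounds shows what a methoxy group does at this position. Compound 1 and compound 3, the two esters bearing trifluoromethyl, both sit low in this assay, and compound 2 alone sits high. Because compound 1 gives 6.4%, compound 4 is expected to move only modestly, with a step of a number 13.6 percentage points higher from compound 1 to compound 4 (beyond the scatter) in this assay that may not exceed the scatter. The estimate for compound 4 is 20%, within a range from 0% to 55%.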

Compound 4, a percentage reported as inhibition, at one concentration (the size of the read-out at that concentration, not a potency): 30.8%
Beside the measured number, compound 4's estimate is 10.8 percentage points below it; measured number inside the range.
By their numbers in this assay, from the lowest: compounds 1 and 3 (each within the scatter of the next); then compound 4; then compound 2.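

Within the data shown here, the exchange of trifluoromethyl for methoxy gives the first reading of what this place on the aromatic ring does in this assay: the step is a number 24.4 percentage points higher from compound 1 to compound 4 (beyond the scatter) and, though modest, it can be told from the scatter. The number therefore responds to the group at this place on the shared core, and the low reading of compound 1 is not fixed by the rest of the structure. The swap removes four heavy atoms and brings in two along with one hydrogen-bond acceptor, but nothing measured here tells which of these differences matters, and no other data bear on the reason for the step.

Going by these compounds, a single exchange gives no trend, so it remains open whether an amine, a hydroxyl group or a longer chain such as ethoxy at this place would carry the number further up or back down. On these data alone, it is also open whether a nitro group on the core of compound 1 would come near the high number of compound 2, which differs from compound 1 in its core as well.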